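Aryl swap on the enone carbon: pyridyl to pyrazolyl

The source may hold more compounds than are shown below. What is called first, only, known or untested is meant among the compounds shown, and "the series" means these compounds.

Measured so far:
- compound 1 `C[C@@H](O[C@H]1CN2C(=O)C=C(c3ccc(F)cc3)CC2[C@@H]1c1ccc(F)cc1)c1cc(C(F)(F)F)cc(C(F)(F)F)c1`: 2 nM
- compound 2 `COc1cc(C2=CC(=O)N3C[C@H](O[C@H](C)c4cc(C(F)(F)F)cc(C(F)(F)F)c4)[C@@H](c4ccc(F)cc4)C3C2)ccn1`: 1.1 nM

Both compounds were run in an assay on CHO cells for displacement of a labelled ligand from Substance-P receptor (Homo sapiens); a higher number here means a weaker inhibitor, a lower number a stronger inhibitor. Within the data shown here, compound 2 gives the lower of the two numbers, yet its single neighbour, compound 1, lies within the scatter: the step of a 1.8-fold lower number from compound 1 to compound 2 (0.26 log units; within the scatter) is too small to rank them.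

Compound 3 `C[C@@H](O[C@H]1CN2C(=O)C=C(c3cnn(C)c3)CC2[C@@H]1c1ccc(F)cc1)c1cc(C(F)(F)F)cc(C(F)(F)F)c1` is not yet measured. It differs from compound 2 in one place: 1-methyl-1H-pyrazol-4-yl in place of 2-methoxypyridin-4-yl on a double-bonded ring carbon.

Among the measured compounds shown here, the only measured step that bears on this position is a 1.8-fold lower number from compound 1 to compound 2 (0.26 log units; within the scatter), a change of the aryl group on the double-bonded ring carbon that stayed within the scatter. That is one data point and it says nothing about a five-membered ring. With no further guidance, the expectation for compound 3 is a number close to that of compound 2, with a wide allowance either way; the estimated step of a 1.8-fold higher number from compound 2 to compound 3 (0.26 log units; within the scatter) is expected to stay within or near the scatter. Compound 3 is estimated at 2 nM in this assay, with a range from 0.6 nM to 8 nM.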

Compound 3, half-maximal inhibitory concentration: 0.13 nM
Beside the measured number, compound 3's estimate is 15-fold (1.19 log units) above it; measured number below the stated range.
By their numbers in this assay, from the lowest: compound 3; then compounds 2 and 1 (each within the scatter of the next).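

In this assay, among these compounds, the aryl group on the double-bonded ring carbon proves able to shift the number beyond the scatter: 1-methyl-1H-pyrazol-4-yl in place of 2-methoxypyridin-4-yl gives an 8.5-fold lower number from compound 2 to compound 3 (0.93 log units; beyond the scatter) and, in place of 4-fluorophenyl, gives a 15-fold lower number from compound 1 to compound 3 (1.19 log units; beyond the scatter) in a step rated large, whereas the one earlier change here could not rank its two compounds. The position therefore distinguishes among aryl groups, with the five-membered aromatic ring carrying 2 hetero atoms giving the lowest number of the three compounds, while the count of hydrogen-bond acceptors stays at 2 and that of donors at 0 across the swap from 2-methoxypyridin-4-yl, and the heavy atoms go from 8 to 6. No measurement on these compounds accounts for the gain.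

Still open, as far as these compounds go, is whether the gain rests on the pyrazole ring itself or on its methyl, a question that 1H-pyrazol-4-yl with a hydrogen on the ring nitrogen, or 1-ethyl-1H-pyrazol-4-yl with a longer chain, would address. Also open, from the compounds shown here alone, is whether other five-membered aromatic rings, such as thiazol-5-yl or 1-methyl-1H-imidazol-4-yl, behave in the same way at this position.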